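Methyl for methoxy across two related cores

The source may hold more compounds than are shown below. What is called first, only, known or untested is meant among the compounds shown, and "the series" means these compounds.

Measured so far:
compound 1 `COc1ccc2[nH]c3c4cn[nH]c4c4c(c3c2c1)C(=O)NC4=O`: 37000 nM
compound 2 `Cc1ccc2[nH]c3c4cn[nH]c4c4c(c3c2c1)C(=O)NC4=O`: 2000 nM
compound 3 `COc1ccc2[nH]c3c(c4c(c5ccnn53)C(=O)NC4=O)c2c1`: "not determined" (no result reported)

In a functional assay on B16-F10 cells (Mus musculus) for cytotoxicity, read by MTT assay, with a stated time of 72 h (on this read-out higher numbers stand for weaker inhibition and lower numbers for stronger inhibition), compound 1 gives 37000 nM, and compound 2 gives 2000 nM. The change between them, (methyl in place of methoxy on an aromatic carbon), produced a 19-fold lower number from compound 1 to compound 2 (1.27 log units; beyond the scatter). Compound 3 has the same atoms as compound 1 joined differently; the difference between the two cores is not broken down here, and compound 3 has no number in this assay. Compound 4 `Cc1ccc2[nH]c3c(c4c(c5ccnn53)C(=O)NC4=O)c2c1` carries the same change on the core of compound 3, (methyl in place of methoxy on an aromatic carbon), at a place described in the same words as for compound 1 to compound 2. With no value for compound 3, the expectation for compound 4 rests on the step from compound 1 to compound 2 alone, and a step of the same size is expected in this assay, though the altered core leaves the range wide. Compound 4 is expected to give 4000 nM in this assay, between 500 nM and 40000 nM.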

Compound 4, half-maximal inhibitory concentration: 37000 nM
Compound 4: the middle estimate sits 9.3-fold (0.97 log units) below what was measured, within the range that was stated.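

For the compounds shown here, compound 3 carries no number in this assay, so no step to compound 4 can be read. From the compounds shown here alone, whether methyl in place of methoxy acts alike on the core of compound 3 and the core of compound 1 stays open. No further data bear on this result.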